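Pyrazole ureas: trifluoromethyl for chloro on the phenol analogue

The source may report more compounds than this note shows. Statements on the series, on what has been measured and on what is new or still open speak of the compounds shown alone.

Compound 1 `COc1cc(-c2nn(-c3cccc(NC(=O)Nc4ccc(Cl)c(Cl)c4)c3)cc2-c2ccncc2)ccc1Cl`: 4480 nM in a functional assay on MOLT-4 cells (Homo sapiens) for inhibition, read by sulforhodamine B assay, with a stated time of 48 h; on this read-out lower numbers stand for stronger inhibition of growth and higher numbers for weaker inhibition of growth.
Compound 2 `O=C(Nc1cccc(-n2cc(-c3ccncc3)c(-c3ccc(Cl)c(O)c3)n2)c1)Nc1ccc(Cl)c(Cl)c1`: > 32500 nM, a limit of this assay.
Compound 3 `COc1cc(-c2nn(-c3cccc(NC(=O)c4ccccc4)c3)cc2-c2ccncc2)ccc1Cl`: > 100000 nM, a limit of this assay.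

Compound 2 stands only at a limit (the limit of > 32500 nM in this assay, at which 1 of the 3 values shown sits), no number below it known. The two measured steps sit elsewhere: an at least 7.2-fold higher number from compound 1 to compound 2 (0.86 log units; beyond the scatter) and an at least 22-fold higher number from compound 1 to compound 3 (1.34 log units; beyond the scatter), both weakening. Going by the values given here, neither touches the change in compound 4 `O=C(Nc1cccc(-n2cc(-c3ccncc3)c(-c3ccc(Cl)c(O)c3)n2)c1)Nc1ccc(Cl)c(C(F)(F)F)c1`, which is trifluoromethyl in place of chloro on an aromatic carbon; no measured pair informs this exchange. Since compound 2 sits at the limit of > 32500 nM in this assay, at which 1 of the 3 values shown sits, and the change is small in kind, compound 4 is expected to remain near a limit, with no step beyond the scatter expected: a step that the limit leaves unreadable from compound 2 to compound 4. The estimate for compound 4 in this assay is 45000 nM, from 10000 nM to 150000 nM.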

Compound 4, concentration for total growth inhibition: 2930 nM
For compound 4 the middle estimate is 15-fold (1.19 log units) above the measured one; the measured number lies below the stated range.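

In this assay, going from 3,4-dichlorophenyl to 4-chloro-3-(trifluoromethyl)phenyl gives an at least 11-fold lower number from compound 2 to compound 4 (1.04 log units; beyond the scatter), the only step shown toward stronger inhibition of growth. The earlier steps shown here showed only losses, whereas this one shows that a single exchange on this ring, with the chloro group kept, turns a limit into a number on the phenol analogue. Compound 2 stands at a limit, so the full size of the step cannot be read: the limit of > 32500 nM in this assay, at which 1 of the 4 values shown sits.

On these data alone, it remains open whether the same exchange holds with the methoxy group of compound 1 in place of the hydroxyl. As far as these compounds go, it is also open whether a nitrile or bromo group at this position would act like trifluoromethyl.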